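A few compounds are considered here, and "the series" means these few. Any claim that something is new, unique, unknown or untested is made for them only; others in the source may bear on it.

Measured in an ADME assay for permeability, using PAMPA, with a stated time of 4 h, at pH 7.4; a lower number here means that the compound crosses the layer more slowly, a higher number that the compound crosses the layer faster:
- compound 1 `NCCCCN(C[C@H]1Cc2ncccc2CN1)[C@H]1CCCc2cccnc21`: 14 nm/s
- compound 2 `NC/C=C\CN(C[C@H]1Cc2ncccc2CN1)[C@H]1CCCc2cccnc21`: 68 nm/s
- compound 3 `CN(CCCCN(C[C@H]1Cc2ncccc2CN1)[C@H]1CCCc2cccnc21)C1CCC(F)(F)CC1`: 310 nm/s

Compound 3 has the highest number of the three. Compound 4 `c1cnc2c(c1)CN[C@@H](CN(CCCC1CCNCC1)[C@H]1CCCc3cccnc31)C2` differs from it as follows: a group of 6 heavy atoms (5 carbon, 1 nitrogen; one six-membered non-aromatic ring with 1 hetero atom) in place of a group of 11 heavy atoms (8 carbon, 1 nitrogen, 2 fluorine; one six-membered non-aromatic ring of carbon only), on a saturated chain carbon, three bonds along the chain from an amine nitrogen. For the measured compounds named here, no measured step shows this exact swap. The closest guide is a 22-fold higher number from compound 1 to compound 3 (1.35 log units; beyond the scatter), where a group with a six-membered non-aromatic ring of carbon only replaced one nitrogen atom. Compound 4 gives up such a ring for piperidin-4-yl, so that step is expected to run largely in reverse. The chain change in a 4.9-fold higher number from compound 1 to compound 2 (0.69 log units; beyond the scatter) bears on it less. A large fall is expected, a 10-fold lower number from compound 3 to compound 4 (1.01 log units; beyond the scatter). For compound 4 the estimated value is 30 nm/s, with an expected range from 10 nm/s to 90 nm/s.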

Compound 4, apparent permeability: 24 nm/s
For compound 4 the middle estimate is 1.3-fold (0.10 log units) above the measured one, and the stated range covers the measured number.
By their numbers in this assay, from the lowest: compounds 1 and 4 (each within the scatter of the next); then compound 2; then compound 3.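

In this assay a six-membered ring at this place does not by itself bring a high number: piperidin-4-yl, with a hydrogen-bond donor that the group it replaces lacks, gives a 13-fold lower number from compound 3 to compound 4 (1.11 log units; beyond the scatter). Compared with the aminomethyl end, the ring gives a 1.7-fold higher number from compound 1 to compound 4 (0.23 log units; within the scatter), while the step from the unsaturated chain is a 2.8-fold lower number from compound 2 to compound 4 (0.45 log units; beyond the scatter). No measured evidence here explains these steps. As far as these compounds go, it remains open whether a plain cyclohexyl group at this place would stay close to compound 3 or fall towards compound 4. The same question stands for a piperidin-4-yl group with a methyl on its nitrogen.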